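The compounds below may be only part of what the source reports. "The series", "measured", "known", "first", "only" and "open" are said of these compounds alone.

Compound 3 `CCc1ccc(C(Nc2ccccn2)c2ccc3cccnc3c2O)cc1` stands lowest of the two numbers shown in an assay for inhibition of protein disulfide-isomerase (Homo sapiens), with a stated time of 1 h (on this read-out higher numbers stand for weaker inhibition and lower numbers for stronger inhibition), where compound 3 gives 170 nM. Compound 1 `Oc1ccc2[nH]ncc2c1C(c1ccc(-c2cncnc2)cc1)N1CCCCC1` gives 830 nM in this assay, a higher number that lies beyond the scatter. Compound 2 `CN(C)c1cccc(C(c2ccc(F)cc2)N2CCCCC2)c1O` gives only a limit in this assay, > 30000 nM, as noted in the limit of > 30000 nM in this assay, at which 1 of the 3 values shown sits.

Compound 4 `Oc1c(C(Nc2ccccn2)c2ccc(Cl)cc2)ccc2cccnc12` has not yet been measured. It differs from compound 3 by chloro in place of ethyl on an aromatic carbon. For the measured compounds named here, no step between measured compounds covers this change, so the expectation rests on compound 3 alone: the step of a 1.5-fold higher number from compound 3 to compound 4 (0.17 log units; within the scatter) is expected to be small, toward a slightly higher number, and within the scatter. Compound 4 is therefore estimated at 250 nM, with a range from 80 nM to 800 nM.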

Compound 4, half-maximal inhibitory concentration: 170 nM
The estimate for compound 4 lay 1.5-fold (0.17 log units) above the measured number; measured number inside the range.
By their numbers in this assay, from the lowest: compounds 3 and 4 (each within the scatter of the next); then compound 1. At a limit, above all of these: compound 2.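

In this assay, replacing ethyl with chloro on the aromatic carbon para to a large group gives no change at the digits printed from compound 3 to compound 4 (within the scatter), so this position accepts either group without a shift beyond the scatter. For the compounds shown here, this is the first one-place comparison, which the earlier compounds, differing in several places, could not provide. Nothing measured here explains the result. From the compounds shown here alone, whether a methoxy group, an amine or a carboxylic acid at this position would keep the number remains open. Two groups alone do not define what this position tolerates.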